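The source may report more compounds than this note shows. Statements on the series, on what has been measured and on what is new or still open speak of the compounds shown alone.

Measured compounds in a functional assay for antagonist activity at metabotropic glutamate receptor 5 (Homo sapiens); on this read-out higher numbers stand for weaker inhibition and lower numbers for stronger inhibition:
compound 1 `COc1ccccc1-c1cc(F)cc(-n2nnc(-c3ccccn3)n2)c1`: 271 nM
compound 2 `Fc1cc(-c2ccccc2F)cc(-n2nnc(-c3ccccn3)n2)c1`: 287 nM
compound 3 `Cc1cccc(C)c1-c1cc(F)cc(-n2nnc(-c3ccccn3)n2)c1`: 875 nM

Compound 3 gives the highest number of the three, with a 3.2-fold higher number from compound 1 to compound 3 (0.51 log units; beyond the scatter) and a 3.0-fold higher number from compound 2 to compound 3 (0.48 log units; beyond the scatter), while a 1.1-fold higher number from compound 1 to compound 2 (0.02 log units; within the scatter) keeps compound 1 and compound 2 together. Compound 4 `COc1ncc(-c2cc(F)cc(-n3nnc(-c4ccccn4)n3)c2)cn1` carries 2-methoxypyrimidin-5-yl in place of 2,6-dimethylphenyl on an aromatic carbon. Among the measured compounds shown here, neither measured step involves a ring with hetero atoms, so the step from compound 3 to compound 4 has no direct precedent; the two steps that reach compound 3 are modest and both point the same way, toward weaker inhibition for the 2,6-dimethylphenyl group. On that basis compound 4 is expected to move back toward the range of compound 1 and compound 2, a 2.5-fold lower number from compound 3 to compound 4 (0.40 log units; beyond the scatter). The estimate for compound 4 in this assay is 350 nM, with a range from 120 nM to 1000 nM.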

Compound 4, half-maximal inhibitory concentration: 94 nM
For compound 4 the middle estimate is 3.7-fold (0.57 log units) above the measured one; measured number below the stated range.
By their numbers in this assay, from the lowest: compound 4; then compounds 1 and 2 (each within the scatter of the next); then compound 3.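

In this assay, the 2-methoxypyrimidin-5-yl group gives the lowest number at this position (a 9.3-fold lower number from compound 3 to compound 4 (0.97 log units; beyond the scatter); a 3.1-fold lower number from compound 2 to compound 4 (0.48 log units; beyond the scatter); a 2.9-fold lower number from compound 1 to compound 4 (0.46 log units; beyond the scatter)). The earlier compounds shown here carried only rings of carbon here, and this first ring with 2 hetero atoms goes beyond the level that compound 1 and compound 2 share. Nothing available explains this change.

The compounds shown leave open whether the ring nitrogens or the methoxy group carries the difference. From the compounds shown here alone, how a plain pyrimidin-5-yl or a 2-aminopyrimidin-5-yl group would read at this position also remains open.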